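The source may report more compounds than this note shows. Statements on the series, on what has been measured and on what is new or still open speak of the compounds shown alone.

For the measured compounds named here, compound 2 `[O-]/[N+](=C\c1cn(CCC(F)(F)C(F)(F)C(F)(F)C(F)(F)C(F)(F)C(F)(F)F)nn1)Cc1ccccc1` is one of the two compounds measured so far. In a functional assay on MDA-MB-231 cells (Homo sapiens) for inhibition, read by MTT assay, with a stated time of 24 h (a higher number here means a weaker inhibitor, a lower number a stronger inhibitor), compound 2 gives only a limit, > 100000 nM, and not a number. Compound 1 `[O-]/[N+](=C\c1cn(CCC(F)(F)C(F)(F)C(F)(F)C(F)(F)C(F)(F)C(F)(F)C(F)(F)C(F)(F)F)nn1)c1ccccc1` is the other measured compound. In this assay compound 1 likewise reaches only a limit, > 100000 nM. Both values shown thus sit at the limit of > 100000 nM in this assay, at which 2 of the 2 values shown sit. Going by the values given here, compound 2 therefore stands at the same limit as compound 1, and no step between measured compounds can be drawn. Compound 3 `[O-]/[N+](=C\c1cn(CCC(F)(F)C(F)(F)C(F)(F)C(F)(F)C(F)(F)C(F)(F)C(F)(F)C(F)(F)F)nn1)Cc1ccccc1` has not yet been measured in this assay. It differs from compound 2 by 1,1,2,2,2-pentafluoroethyl in place of fluoro on a saturated chain carbon bound to two fluorine atoms and a saturated chain carbon. With both known values at the limit, no step beyond the scatter is expected from compound 2 to compound 3, and the estimated step is a step that the limit leaves unreadable from compound 2 to compound 3. Compound 3 is accordingly estimated at 150000 nM, with a range from 60000 nM to 400000 nM, most likely again reported only as a limit.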

Compound 3, half-maximal inhibitory concentration: 8400 nM
Compound 3: middle estimate off by 18-fold (1.25 log units), on the high side; the measured number lies below the stated range.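

For the compounds shown here, compound 3 gives the only number that can be read in this assay, and it shows that this chain position responds to the change: 1,1,2,2,2-pentafluoroethyl in place of fluoro on a saturated chain carbon bound to two fluorine atoms and a saturated chain carbon gives an at least 11-fold lower number from compound 2 to compound 3 (1.07 log units; beyond the scatter) on the chain side. The group on the double-bonded nitrogen also matters, as benzyl in place of phenyl gives an at least 11-fold lower number from compound 1 to compound 3 (1.07 log units; beyond the scatter) with the chain held the same. Both steps are only minimum sizes, since compound 1 and compound 2 remain at a limit: the limit of > 100000 nM in this assay, at which 2 of the 3 values shown sit.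

Going by these compounds, the true size of either step therefore stays open. On these data alone, it also stays open whether a longer perfluoroalkyl chain would lower the number further, or whether a plain hydrocarbon chain would do the same at this position.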